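Cyclopentyl in place of sec-butyl: compound 1 to compound 4

This account rests on a few compounds, and the source may have more. Where it says the series, first, only, none or still open, it means among the compounds named here.

Measured so far in a functional assay on NCI-H460 cells (Homo sapiens) for antiproliferative activity, read by CCK-8 assay, with a stated time of 72 h; on this read-out higher numbers stand for weaker inhibition and lower numbers for stronger inhibition:
compound 1 `CCC(C)n1cnc2c(NCc3ccc(C(=O)Nc4ccccc4N)cc3)nc(Cl)nc21` gives 4940 nM
compound 2 `CC1CCN(c2nc(Cl)nc3c2ncn3Cc2ccc(C(=O)Nc3ccccc3N)cc2)CC1` gives 7400 nM
compound 3 `Nc1ccccc1NC(=O)c1ccc(Cn2cnc3c(Nc4cccc(Cl)c4)nc(Cl)nc32)cc1` gives 6580 nM

All three numbers sit close together. Compound 1 cannot be set apart from compound 3 or from compound 2, since both gaps fall inside the usual scatter of repeated measurements. Going by the values given here, the one step between measured compounds that differ in a single place, a 1.1-fold lower number from compound 2 to compound 3 (0.05 log units; within the scatter), concerns the substituent on an aromatic carbon and likewise stays within the scatter.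

Compound 4 `Nc1ccccc1NC(=O)c1ccc(CNc2nc(Cl)nc3c2ncn3C2CCCC2)cc1` is the next compound. It differs from compound 1 in one place: cyclopentyl in place of sec-butyl on an aromatic nitrogen. Among the compounds with values here, no measured pair probes a change at this aromatic nitrogen, so the step from compound 2 to compound 3 does not bear on it, and the series offers no direct precedent. With three compounds of different shape all giving numbers within the scatter of one another, the working expectation is that compound 4 will also fall in that band, with no step beyond the scatter in either direction.

For compound 4 the estimated result is 4500 nM, with a range from 1500 nM to 13000 nM, which means an expected step of a 1.1-fold lower number from compound 1 to compound 4 (0.04 log units; within the scatter) from compound 1.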

Compound 4, half-maximal inhibitory concentration: 5780 nM
The estimate for compound 4 lay 1.3-fold (0.11 log units) below the measured number; the measured number falls inside the stated range.
By their numbers in this assay, from the lowest: compounds 1, 4, 3 and 2 (each within the scatter of the next).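

In this assay, replacing the open sec-butyl with cyclopentyl, a five-membered non-aromatic ring of carbon only, on the aromatic nitrogen gives no readable change (a 1.2-fold higher number from compound 1 to compound 4 (0.07 log units; within the scatter)). Going by these compounds alone, this is the first pair to probe this aromatic nitrogen, and closing the substituent into a ring does not separate the two compounds. The data give no measurement that would explain this result, so the flat step stands only as an observation.

Going by these compounds, both substituents compared here consist of carbon alone, so it remains open whether a group of another kind on this nitrogen, such as a chain ending in an amine or a carboxylic acid, would move the number beyond the scatter. Cyclohexyl or a phenyl ring at the same place would show whether the flat response extends to larger or aromatic rings, and until such a step leaves the scatter, this position cannot be said to matter or not to matter in this assay.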